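From benzoyl to (4-nitrophenyl)carbonyl on a shared core

The source may report more compounds than this note shows. Statements on the series, on what has been measured and on what is new or still open speak of the compounds shown alone.

Compound 1 `C=C1C(=O)[C@@]23C(=O)OC[C@]4([C@@H](OC(C)=O)CCC(C)(C)[C@H]4C=O)[C@@H]2CC[C@@H]1[C@H]3O` gives 9560 nM
Compound 2 `C=C1C(=O)[C@@]23C(=O)OC[C@]4(C(=O)CCC(C)(C)[C@H]4C=O)[C@@H]2CC[C@@H]1[C@H]3OC(=O)CC` gives 1310 nM
Compound 3 `C=C1C(=O)[C@@]23C(=O)OC[C@]4(C(=O)CCC(C)(C)[C@H]4C=O)[C@@H]2CC[C@@H]1[C@H]3OC(=O)c1ccccc1` gives 1480 nM

All three values come from a functional assay on K562 cells (Homo sapiens) for cytotoxicity, read by MTT assay, with a stated time of 72 h; on this read-out higher numbers stand for weaker inhibition and lower numbers for stronger inhibition. Compound 3 sits level with compound 2, within the scatter of repeated measurements, while compound 1 shows a clearly higher number than either. The next compound to consider is compound 4 `C=C1C(=O)[C@@]23C(=O)OC[C@]4(C(=O)CCC(C)(C)[C@H]4C=O)[C@@H]2CC[C@@H]1[C@H]3OC(=O)c1ccc([N+](=O)[O-])cc1`, which keeps the core and the benzoyloxy arrangement of compound 3 but changes the phenyl ring: nitro in place of hydrogen on an aromatic carbon.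

Among the measured compounds shown here, only one measured step bears on this change. Phenyl in place of ethyl on a carbonyl carbon gave a 1.1-fold higher number from compound 2 to compound 3 (0.05 log units; within the scatter), so that a substantial change at this carbonyl carbon left the number in this assay essentially unmoved. For the measured compounds named here, no measured compound carries a nitro group, so the evidence is indirect, and no shift beyond the scatter is expected. The expected step is a 1.1-fold lower number from compound 3 to compound 4 (0.06 log units; within the scatter). For compound 4 the estimated value is 1300 nM, with an expected range from 600 nM to 3000 nM.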

Compound 4, half-maximal inhibitory concentration: 1330 nM
The estimate for compound 4 lay 1.0-fold (0.01 log units) below the measured number; the measured number falls inside the stated range.
By their numbers in this assay, from the lowest: compounds 2, 4 and 3 (each within the scatter of the next); then compound 1.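

In this assay, nitro in place of hydrogen on an aromatic carbon, para to a large group, gives a 1.1-fold lower number from compound 3 to compound 4 (0.05 log units; within the scatter), so this first change on the phenyl ring itself leaves the number within the scatter. Comparing the two ends of the series, 4-nitrophenyl in place of ethyl on a carbonyl carbon gives a 1.0-fold higher number from compound 2 to compound 4 (0.01 log units; within the scatter), which places the ethyl, phenyl and 4-nitrophenyl forms level with one another among the compounds shown, where the earlier compounds had offered only the comparison of ethyl with phenyl. No data shown here offer any explanation for this flat result.

As far as these compounds go, whether the number would stay level with an amine or a carboxylic acid in place of the nitro group on the ring, or with a longer chain in place of ethyl on the carbonyl carbon, remains open. The compounds shown also leave open whether nitro on a different aromatic carbon of the ring would give a similar number.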